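The compounds below may be only part of what the source reports. "The series", "measured", "known", "first", "only" and "open" are said of these compounds alone.

Compound 1, `CCOC(=O)[C@H](CCC(=O)O)NC(=O)c1ccc(Sc2nc3cc(N)cc(N)c3nc2-c2ccccc2)cc1`, and compound 2, `Nc1cc(N)c2nc(-c3ccccc3)c(Oc3ccc(F)cc3)nc2c1`, were both tested in a functional assay on SF-268 cells (Homo sapiens) for inhibition, read by sulforhodamine B assay, with a stated time of 48 h; on this read-out higher numbers stand for lower toxicity in this test and lower numbers for higher toxicity in this test. For compound 1 this assay reports only a limit, < 100000 nM. For compound 2 this assay likewise reports only a limit, < 100000 nM. Compound 2 thus stands where every value shown stands: the limit of < 100000 nM in this assay, at which 2 of the 2 values shown sit. Compound 3, `Nc1cc(N)c2nc(-c3ccccc3)c(NCc3ccc(F)cc3)nc2c1`, has not yet been tested; it differs from compound 2 by (4-fluorobenzyl)amino in place of 4-fluorophenoxy on an aromatic carbon. Going by the values given here, with no measured step to draw on, the step from compound 2 to compound 3 is expected to be a step that the limit leaves unreadable from compound 2 to compound 3, nothing beyond the scatter. Compound 3 is estimated at 30000 nM, in a range from 5000 nM to 100000 nM.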

Compound 3, concentration lethal to 50% of the cells: 40700 nM
Beside the measured number, compound 3's estimate is 1.4-fold (0.13 log units) below it; the range from low to high includes it.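

No step can be read from compound 2 to compound 3, because compound 2 has only a limit, not a number: the limit of < 100000 nM in this assay, at which 2 of the 3 values shown sit.

The compounds shown leave open whether (4-fluorobenzyl)amino in place of 4-fluorophenoxy changes the read-out at all, and in which direction.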